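Replacing a ring amine with an open chain in compound 2

The compounds below may be only part of what the source reports. "The series", "measured", "known", "first", "only" and "open" are said of these compounds alone.

The series shares one core, shown in compound 1 `CCSc1ccccc1Nc1nc(Nc2ccc(N3CCN(C)CC3)cc2OC)ncc1Cl`, compound 2 `CC[S+]([O-])c1cc(F)ccc1Nc1nc(Nc2ccc(N3CCC(N(C)C)CC3)cc2OC)ncc1Cl` and compound 3 `COc1cc(N2CCN(C)CC2)ccc1Nc1ncc(Cl)c(Nc2ccccc2[S+]([O-])C(C)C)n1`. In a functional assay on NCI-H2228 cells (Homo sapiens) for inhibition, read by CCK-8 assay (on this read-out higher numbers stand for weaker inhibition and lower numbers for stronger inhibition), compound 1 gives 981 nM, compound 2 gives 337 nM and compound 3 gives 82.9 nM. Compound 2 therefore stands second highest of the three numbers: compound 1 lies nearest, and compound 3 is furthest.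

Compound 4 `CC[S+]([O-])c1cc(F)ccc1Nc1nc(Nc2ccc(N(C)CCN(C)C)cc2OC)ncc1Cl` has not yet been measured. It differs from compound 2 in one place: (2-(dimethylamino)ethyl)(methyl)amino in place of 4-(dimethylamino)piperidin-1-yl on an aromatic carbon.

For the measured compounds named here, the only measured step among the three compounds is a 12-fold lower number from compound 1 to compound 3 (1.07 log units; beyond the scatter), and it concerns a different place on the core, so it does not bear on this change. Going by the values given here, no measured pair in this set alters the group on the aromatic carbon that is changed here, so nothing in the data points to a step beyond the scatter in either direction.

Compound 4 is therefore expected to give about 400 nM, within a range of 150 nM to 1100 nM, which means an expected step of a 1.2-fold higher number from compound 2 to compound 4 (0.07 log units; within the scatter).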

Compound 4, half-maximal inhibitory concentration: 84.3 nM
Estimate against measurement, compound 4: 4.7-fold (0.68 log units) above; measured number outside the range, below it.
By their numbers in this assay, from the lowest: compounds 3 and 4 (each within the scatter of the next); then compound 2; then compound 1.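

In this assay, for the compounds shown here, the open (2-(dimethylamino)ethyl)(methyl)amino group in place of 4-(dimethylamino)piperidin-1-yl gives a 4.0-fold lower number from compound 2 to compound 4 (0.60 log units; beyond the scatter), which shows that the group at this place, para to a large group, can shift the read-out; the earlier compounds could not show this, as their only measured step lay elsewhere on the core. Both groups have the same hydrogen-bond donor and acceptor counts, so the step goes with the loss of the six-membered ring and the smaller number of heavy atoms in the entering group, and these two differences cannot be separated here. Nothing available explains why the open chain gives the lower number.

From the compounds shown here alone, how a morpholine ring or a longer chain ending in a diethylamino group would read at this place remains open. Also open, going by these compounds, is whether the same exchange would give a step of similar size on compound 1 or compound 3.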